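A few compounds are considered here, and "the series" means these few. Any claim that something is new, unique, unknown or untested is made for them only; others in the source may bear on it.

Compound 1, `Cc1oc(-c2c(Cl)cccc2Br)nc1CN1CCC(C(=O)NCCCN2C[C@H](C)C[C@H](C)C2)CC1`, and compound 2, `CCCN(CCC)CCNC(=O)C1CCN(Cc2nc(-c3ccccc3C)oc2C)CC1`, were both examined in an ADME assay on Huh7.5.1 cells (Homo sapiens) for cytotoxicity, read by ATP content, with a stated time of 48 h; on this read-out lower numbers stand for higher toxicity in this test and higher numbers for lower toxicity in this test. Compound 1 gives 12200 nM in this assay, while compound 2 gives 30500 nM. Of the two numbers, compound 1 stands lowest; compound 2 is its nearest neighbour, with a value that is higher by a margin beyond the usual scatter, so compound 1 is the more cytotoxic of the pair in this assay.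

Compound 3, `Cc1cccc(C)c1-c1nc(CN2CCC(C(=O)NCCCN3C[C@H](C)C[C@H](C)C3)CC2)c(C)o1`, has not yet been measured in this assay. Its structure differs from compound 1 in one place: 2,6-dimethylphenyl in place of 2-bromo-6-chlorophenyl on an aromatic carbon.

Among the compounds with values here, no pair of measured compounds differing only in this way is available, so the effect of this exchange on this assay cannot be read directly from the numbers. Compound 3 is expected to show a modest step, a 1.6-fold higher number from compound 1 to compound 3 (0.21 log units; within the scatter), toward a higher number than compound 1, of a size near the edge of the scatter. The estimate for compound 3 in this assay is 20000 nM, with a range from 8000 nM to 50000 nM.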

Compound 3, half-maximal cytotoxic concentration: 21000 nM
Compound 3: middle estimate off by 1.1-fold (0.02 log units), on the low side; measured number inside the range.
By their numbers in this assay, from the lowest: compounds 1, 3 and 2 (each within the scatter of the next, the first and the last beyond it).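

Within the data shown here, compounds 1 and 3 form the first pair that differs only at this aromatic carbon, and exchanging 2-bromo-6-chlorophenyl for 2,6-dimethylphenyl gives a 1.7-fold higher number from compound 1 to compound 3 (0.24 log units; within the scatter) in this assay. The chlorine and the bromine both leave and carbon takes their places, while the count of heavy atoms stays the same, and the read-out does not separate the two compounds, so in this pair the cytotoxicity number does not depend on those two halogens being present. Nothing given here bears on why the exchange leaves the number within the scatter.

On these data alone, a single pair describes only these two groups on this carbon, so it remains open how a 2,6-dichlorophenyl, a 2,6-dimethoxyphenyl, an unsubstituted phenyl or a pyridine ring would read in this assay. As far as these compounds go, it also remains open whether the same exchange would read alike with another amine at the far end of the amide chain, or with a carboxylic acid there, since compound 2 differs from compound 1 in more than one place and offers no such comparison.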